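This account rests on a few compounds, and the source may have more. Where it says the series, first, only, none or still open, it means among the compounds named here.

Of the compounds shown here, three built on the same core have been tested in a functional assay on HL-60 cells (Homo sapiens) for antiproliferative activity, read by MTT assay, with a stated time of 48 h; a lower number here means a stronger inhibitor, a higher number a weaker inhibitor. Compound 1 `CC(C)=CCC[C@]1(C)/C=C/[C@@H](OC(=O)C=C(C)C)[C@](C)(O)/C=C/C(=O)/C(CN(C(C)C)C(C)C)=C\C1` gives 740 nM. Compound 2 `CC(C)=CCC[C@]1(C)/C=C/[C@@H](OC(=O)C=C(C)C)[C@](C)(O)/C=C/C(=O)/C(CN2CCCC2)=C\C1`, which carries pyrrolidin-1-yl in place of diisopropylamino on a saturated chain carbon bound to a double-bonded ring carbon, gives 160 nM, a change of a 4.6-fold lower number from compound 1 to compound 2 (0.67 log units; beyond the scatter). Compound 3 `COCOC/C1=C/C[C@](C)(CCC=C(C)C)/C=C/[C@@H](OC(=O)C=C(C)C)[C@](C)(O)/C=C/C1=O`, with methoxymethoxy at that same saturated chain carbon, gives 2840 nM, the highest of the three numbers; the steps leading to it are a 3.8-fold higher number from compound 1 to compound 3 (0.58 log units; beyond the scatter) and an 18-fold higher number from compound 2 to compound 3 (1.25 log units; beyond the scatter). Both compounds bearing an amine there have lower numbers than compound 3, though by different amounts.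

Compound 4 `CCN(CC)C(=O)/C1=C/C[C@](C)(CCC=C(C)C)/C=C/[C@@H](OC(=O)C=C(C)C)[C@](C)(O)/C=C/C1=O` alters compound 3 in one place: diethylcarbamoyl in place of (methoxymethoxy)methyl on a double-bonded ring carbon. Among the compounds with values here, no measured step matches this change. The measured steps swapped one group for another on the saturated chain carbon, whereas here the (methoxymethoxy)methyl chain is removed altogether and diethylcarbamoyl sits directly on the double-bonded ring carbon. Within the data shown here, none of the measured compounds carries a carbonyl at that position, so the data show only that this position accepts a spread of groups with modest to large shifts. Compound 4 is expected to remain near compound 3, with an expected step of a 1.1-fold higher number from compound 3 to compound 4 (0.02 log units; within the scatter) and wide uncertainty. The estimate for compound 4 in this assay is 3000 nM, within a range from 800 nM to 12000 nM.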

Compound 4, half-maximal inhibitory concentration: 9080 nM
Beside the measured number, compound 4's estimate is 3.0-fold (0.48 log units) below it; the range from low to high includes it.
By their numbers in this assay, from the lowest: compound 2; then compound 1; then compound 3; then compound 4.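

In this assay, the position is shown not to be indifferent to a group carried directly on the double-bonded ring carbon: with diethylcarbamoyl in place of (methoxymethoxy)methyl, there is a 3.2-fold higher number from compound 3 to compound 4 (0.50 log units; beyond the scatter), and this is the highest number of the four compounds. The gaps to the two amine-bearing compounds are wider, with a 12-fold higher number from compound 1 to compound 4 (1.09 log units; beyond the scatter) and a 57-fold higher number from compound 2 to compound 4 (1.75 log units; beyond the scatter), so a nitrogen within diethylcarbamoyl does not bring the lower numbers seen when diisopropylamino or pyrrolidin-1-yl sits on the saturated chain carbon. No measurement offered here accounts for these shifts.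

The change from compound 3 to compound 4 alters both the chain and the atoms attached to the ring carbon, so the compounds shown cannot separate the loss of the saturated chain carbon from the arrival of the carbonyl. A diethylaminomethyl group would test the same ethyl groups on an amine at the saturated chain carbon, and a pyrrolidine-1-carbonyl group would test the ring of compound 2 with a carbonyl attached directly to the double-bonded ring carbon.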